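The source may report more compounds than this note shows. Statements on the series, on what has been measured and on what is new or still open speak of the compounds shown alone.

Compound 3 `C=CCn1c(=O)/c(=C\c2cccc(Cl)c2Cl)[nH]c(=O)/c1=C\c1ccccc1OC` stands at the lowest number of the two compounds that returned a figure in a functional assay on BGC-823 cells (Homo sapiens) for cytotoxicity, read by CCK-8 assay, with a stated time of 72 h; on this read-out lower numbers stand for stronger inhibition and higher numbers for weaker inhibition; in this assay compound 3 gives 2200 nM. Its nearest neighbour is compound 2 `C=CCn1c(=O)/c(=C\c2ccccc2Cl)[nH]c(=O)/c1=C\c1ccccc1OC`, which gives 4600 nM; the step of a 2.1-fold lower number from compound 2 to compound 3 (0.32 log units; beyond the scatter) consists of a chloro in place of hydrogen on an aromatic carbon. A third compound, compound 1 `COc1ccccc1/C=c1/[nH]c(=O)/c(=C\c2ccccc2OC)n(C)c1=O`, also carries two 2-methoxyphenyl groups, and in this assay compound 1 is recorded as "not active" (no number reported).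

The next compound, compound 4 `C=CCn1c(=O)/c(=C\c2ccccc2OC)[nH]c(=O)/c1=C\c1ccccc1OC`, differs from compound 3 by a single change: 2-methoxyphenyl in place of 2,3-dichlorophenyl on a double-bonded chain carbon bound to an aromatic carbon. Compound 4 thus carries 2-methoxyphenyl groups on both double-bonded chain carbons, as compound 1 does. Within the data shown here, no measured step covers this exact exchange. Among the measured compounds shown here, the only step available, a 2.1-fold lower number from compound 2 to compound 3 (0.32 log units; beyond the scatter), moved toward a lower number when a chloro was added, and the change here takes both chlorines away, so the reverse direction is expected. Compound 1, the closest structural relative of compound 4, returned no number at all. Compound 4 is therefore expected to give a higher number, a 6.8-fold higher number from compound 3 to compound 4 (0.83 log units; beyond the scatter), with a real chance that it too comes back without a figure. The estimate for compound 4 is 15000 nM, within a range from 5000 nM to 50000 nM.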

Compound 4, half-maximal inhibitory concentration: 13400 nM
Compound 4: the middle estimate sits 1.1-fold (0.05 log units) above what was measured; the range from low to high includes it.
By their numbers in this assay, from the lowest: compound 3; then compound 2; then compound 4.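

At this place, on a double-bonded chain carbon bound to an aromatic carbon, the series now holds three aromatic groups with figures, and in this assay the step of a 6.1-fold higher number from compound 3 to compound 4 (0.78 log units; beyond the scatter) shows that exchanging 2,3-dichlorophenyl for 2-methoxyphenyl costs more than the earlier gain from adding one chloro. The second step, a 2.9-fold higher number from compound 2 to compound 4 (0.46 log units; beyond the scatter), shows that replacing a single chloro with methoxy is enough on its own to raise the number beyond the scatter, so compound 4 has the highest figure of the three and the order runs from two chlorines through one chlorine to methoxy. Compound 4 also carries the same two 2-methoxyphenyl groups as compound 1, yet it still returns a figure, so these two groups do not by themselves rule out a number on this read-out. From the compounds shown here alone, what remains open is whether chloro helps or methoxy hurts, since a plain phenyl ring would be needed as a reference point, and whether a fluoro, a nitrile or a carboxylic acid on this ring would follow the same order. Nothing in the data shown bears on why these numbers differ.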